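Working notes: from compound 3 to compound 4

The source may hold more compounds than are shown below. What is called first, only, known or untested is meant among the compounds shown, and "the series" means these compounds.

Measured in a functional assay on PC-3 cells (Homo sapiens) for antiproliferative activity, read by MTT assay, with a stated time of 48 h; on this read-out higher numbers stand for weaker inhibition and lower numbers for stronger inhibition:
- compound 1 `CCn1c(C(=O)N(CCC#N)CCC#N)ccc1C(CC)(CC)c1ccc(OCCC(O)(CC)CC)c(C)c1` gives > 50000 nM as a limit
- compound 2 `CCOc1ccc(NC(=O)c2ccc(C(CC)(CC)c3ccc(OCCC(O)(CC)CC)c(C)c3)n2CC)cc1` gives > 50000 nM as a limit
- compound 3 `CCn1c(C(=O)N(C)CC(=O)O)ccc1C(CC)(CC)c1ccc(OCCC(O)(CC)CC)c(C)c1` gives 2250 nM as a number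

Among the compounds with values here, compound 3 is the only compound here with a readable number. The other two stand at the limit of > 50000 nM in this assay, at which 2 of the 3 values shown sit, and give no number.

Compound 4 `CCC(C)C(CO)NC(=O)c1ccc(C(CC)(CC)c2ccc(OCCC(O)(CC)CC)c(C)c2)n1CC` keeps the shared core. The change is (1-(hydroxymethyl)-2-methylbutyl)amino in place of (carboxymethyl)(methyl)amino on a carbonyl carbon and nothing else differs: (1-(hydroxymethyl)-2-methylbutyl)amino in place of (carboxymethyl)(methyl)amino on a carbonyl carbon.

Two measured steps at this same place bear on it. They are an at least 22-fold lower number from compound 1 to compound 3 (1.34 log units; beyond the scatter) and an at least 22-fold lower number from compound 2 to compound 3 (1.34 log units; beyond the scatter) and both arrive at the group that compound 4 gives up. The remaining one, a step that the two limits leave unreadable from compound 1 to compound 2 adds nothing on size. Read backwards, the two large steps mean that both replacements of the group in compound 3 ended at the limit. Within the data shown here, no measured compound carries the entering group, so the size of the loss is uncertain, and compound 4 may also reach the limit.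

The expected step is a 5.3-fold higher number from compound 3 to compound 4 (0.73 log units; beyond the scatter) toward a higher number and weaker inhibition. For compound 4 the estimate is 12000 nM in this assay with an expected range of 2500 nM to 50000 nM overall.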

Compound 4, half-maximal inhibitory concentration: 28400 nM
Compound 4: the middle estimate sits 2.4-fold (0.37 log units) below what was measured; low and high end bracket the measured number.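

In this assay, the third replacement on this carbonyl carbon gives the first loss that can be sized, a 13-fold higher number from compound 3 to compound 4 (1.10 log units; beyond the scatter), and compound 3 remains the strongest of the four, with (carboxymethyl)(methyl)amino unmatched by any other group shown here. The comparison with the other two compounds gives only floors, an at least 1.7-fold lower number from compound 2 to compound 4 (0.24 log units; that floor lies within the scatter) and an at least 1.7-fold lower number from compound 1 to compound 4 (0.24 log units; that floor lies within the scatter), so the (1-(hydroxymethyl)-2-methylbutyl)amino group cannot be clearly separated from the groups in compound 1 and compound 2. Compound 1 and compound 2 have limits rather than numbers, which leaves only two readable values at this position: the limit of > 50000 nM in this assay, at which 2 of the 4 values shown sit.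

The compounds shown do not separate the contribution of the carboxylic acid from that of the methyl on the amide nitrogen, and the plain (carboxymethyl)amino group or (2-hydroxyethyl)(methyl)amino would address that directly. From the compounds shown here alone, it also remains open whether a longer chain, such as (2-carboxyethyl)(methyl)amino, would hold the number of compound 3, and whether the branched chain or the hydroxymethyl in compound 4 goes with its higher number.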